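The source may hold more compounds than are shown below. What is called first, only, known or untested is meant among the compounds shown, and "the series" means these compounds.

Measured compounds in a functional assay on A2780 cells (Homo sapiens) for inhibition, read by trypan blue exclusion, with a stated time of 72 h; a higher number here means a weaker inhibitor of growth, a lower number a stronger inhibitor of growth:
- compound 1, `Cc1c(-c2ccc(O)c(O)c2)n(CCCCOc2ccccc2)c2ccc(O)cc12`: 4300 nM
- compound 2, `Cc1c(-c2ccc(O)cc2)n(CCCCOc2ccccc2)c2ccc(O)cc12`: 2000 nM
- compound 3, `Cc1c(-c2ccc(O)cc2)[nH]c2ccccc12`: > 20000 nM

For compound 3 the value is a limit of this assay, not a number, and it sits at the limit of > 20000 nM in this assay, at which 1 of the 3 values shown sits.

Compound 2 and compound 1 differ in one place, (hydroxy in place of hydrogen on an aromatic carbon), and the step is a 2.2-fold higher number from compound 2 to compound 1 (0.33 log units; beyond the scatter). The difference between the core of compound 3 and the core of compound 2 is not broken down here.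

Not yet measured is compound 4, `Cc1c(-c2ccc(O)cc2)[nH]c2ccc(O)cc12`. It differs from compound 3 by hydroxy in place of hydrogen on an aromatic carbon. This is the same kind of change as that from compound 2 to compound 1, but not the same: there the hydroxy enters ortho to a hydroxy group and meta to a large group, whereas here it enters on a ring that is part of a fused or bridged system of two rings, meta and para to a fused ring.

For the measured compounds named here, since compound 3 shows only a limit in this assay, and the one measured step of this kind is modest, compound 4 is expected to remain near that limit; the expected step is a step that the limit leaves unreadable from compound 3 to compound 4. The estimate for compound 4 in this assay is 25000 nM, from 8000 nM to 80000 nM.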

Compound 4, concentration for 50% growth inhibition: 11000 nM
Compound 4: the middle estimate sits 2.3-fold (0.36 log units) above what was measured; low and high end bracket the measured number.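

In this assay the value of compound 3 is a limit, not a number: the limit of > 20000 nM in this assay, at which 1 of the 4 values shown sits.

Hydroxy in place of hydrogen on an aromatic carbon gives an at least 1.8-fold lower number from compound 3 to compound 4 (0.25 log units; that floor lies within the scatter), and set beside the earlier step, this change does not carry over with the same direction from one core to the other: the same change on two cores in this assay, a 2.2-fold higher number (0.33 log units; beyond the scatter) from compound 2 to compound 1 and an at least 1.8-fold lower number (0.25 log units; that floor lies within the scatter) from compound 3 to compound 4, at least 3.9-fold (0.59 log units) apart, beyond the scatter of two such steps

On these data alone, this does not show whether the core or the place of entry separates the two steps, as the hydroxy enters a different kind of ring in each pair, and the size of the step to compound 4 remains unknown, with only its floor available.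

Still open, as far as these compounds go, is how the same hydroxy change behaves when core and place of entry are varied one at a time. Also open, from the compounds shown here alone, is whether a methoxy group, a fluorine atom or an amine at the place taken by the hydroxy of compound 4 would shift the number in this assay in the same way.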